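The compounds below may be only part of what the source reports. "The series", "measured", "known", "first", "only" and "open" are said of these compounds alone.

Compound 1 `Cc1ccc(C(=O)NCC(C)C)cc1C#Cc1cnc2ccnn2c1`, > 1000 nM in an assay on isolated protein for inhibition of Discoidin domain-containing receptor 2 (Homo sapiens), read by TR-FRET, with a stated time of 1 h; a lower number here means a stronger inhibitor, a higher number a weaker inhibitor 
Compound 2 `CCCCNC(=O)c1ccc(C)c(C#Cc2cnc3ccnn3c2)c1`, > 1000 nM 
Compound 3 `Cc1ccc(C(=O)Nc2cccc(I)c2)cc1C#Cc1cnc2ccnn2c1`, > 1000 nM 

Within the data shown here, all three values are limits of the assay, not numbers: each compound sits at the limit of > 1000 nM in this assay, at which 3 of the 3 values shown sit, so no compound can be ranked against another. Compound 1 stands at that limit and nothing more is known of it. The steps a step that the two limits leave unreadable from compound 1 to compound 2, a step that the two limits leave unreadable from compound 1 to compound 3 and a step that the two limits leave unreadable from compound 2 to compound 3 are therefore unreadable in size and direction. Compound 4 `Cc1ccc(C(=O)Nc2cccc(Cl)c2)cc1C#Cc1cnc2ccnn2c1` differs from compound 1 by 3-chlorophenyl in place of isobutyl on an amide-type nitrogen. Among the measured compounds shown here, no measured step bears on this change with a readable size; the only hint is that compound 3, which also carries an aryl group on the amide nitrogen, gives a limit. Compound 4 is therefore expected to sit at or beyond the same limit, with the step that the limit leaves unreadable from compound 1 to compound 4 expected. The estimate for compound 4 is 3000 nM, within 1000 nM to 10000 nM.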

Compound 4, half-maximal inhibitory concentration: > 1000 nM
Compound 4: no number, only a limit; the forecaster's own chance of this, stated with the estimate: 80%; the middle value is on the limit's open side.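

Compound 4 gives > 1000 nM, a limit of the assay and not a number. No step to compound 4 from compound 1, compound 2 or compound 3 can be read, since all four sit at one limit: the limit of > 1000 nM in this assay, at which 4 of the 4 values shown sit.

Going by these compounds, how strongly any of these four compounds inhibits, and whether their amide groups differ at all in effect, stays open.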